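The source may hold more compounds than are shown below. What is called first, only, known or untested is meant among the compounds shown, and "the series" means these compounds.

Two compounds built on the same core differ only in the halogen-bearing phenyl attached to an aromatic nitrogen. Compound 1 `N#CC1=C(N)Oc2c(c3nc4ccccc4nc3c3ccccc23)C12C(=O)N(Cc1cnnn1-c1ccccc1Cl)c1ccccc12` gives 42600 nM in a functional assay on A549 cells (Homo sapiens) for antiproliferative activity, read by MTT assay, with a stated time of 48 h; a higher number here means a weaker inhibitor, a lower number a stronger inhibitor. Compound 2 `N#CC1=C(N)Oc2c(c3nc4ccccc4nc3c3ccccc23)C12C(=O)N(Cc1cnnn1-c1cccc(Cl)c1)c1ccccc12` gives 32600 nM in this assay. The step from one to the other, a 1.3-fold lower number from compound 1 to compound 2 (0.12 log units; within the scatter), lies within the scatter, so compound 2 has the lower of the two numbers without standing apart from compound 1.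

Compound 3 `N#CC1=C(N)Oc2c(c3nc4ccccc4nc3c3ccccc23)C12C(=O)N(Cc1cnnn1-c1ccc(Br)cc1)c1ccccc12` has not yet been measured. It differs from compound 2 in one place: 4-bromophenyl in place of 3-chlorophenyl on an aromatic nitrogen. For the measured compounds named here, the only measured step that bears on this exchange, a 1.3-fold lower number from compound 1 to compound 2 (0.12 log units; within the scatter), also swapped one halogen-bearing phenyl for another on the same aromatic nitrogen and produced nothing beyond the scatter. On that basis, the expected step of a 1.0-fold lower number from compound 2 to compound 3 (0.01 log units; within the scatter) is within the scatter. Compound 3 is therefore estimated to give about 32000 nM in this assay, with a range from 14000 nM to 70000 nM.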

Compound 3, half-maximal inhibitory concentration: 44300 nM
Estimate against measurement, compound 3: 1.4-fold (0.14 log units) below; low and high end bracket the measured number.
By their numbers in this assay, from the lowest: compounds 2, 1 and 3 (each within the scatter of the next).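

The earlier pair changed only where a chlorine sat on the phenyl. Compound 3 changes the halogen as well, yet in this assay the exchange for 4-bromophenyl stays within the scatter against both 3-chlorophenyl (a 1.4-fold higher number from compound 2 to compound 3 (0.13 log units; within the scatter)) and 2-chlorophenyl (a 1.0-fold higher number from compound 1 to compound 3 (0.02 log units; within the scatter)). Across these three compounds, then, neither the identity of the halogen nor its place on the phenyl on this aromatic nitrogen separates the numbers, and no measurement at hand offers an explanation.

Still open, from the compounds shown here alone, is whether any group here can move the number beyond the scatter, for instance an unsubstituted phenyl, a phenyl carrying an amine or a carboxylic acid, or a longer alkyl chain on the same nitrogen. A 4-chlorophenyl would also allow the halogen and its place to be compared one at a time.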